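The compounds below may be only part of what the source reports. "The series", "measured", "known", "first", "only" and "open" are said of these compounds alone.

Compound 1 `CC1=CC[C@@H]([C@@](C)(O)CCCC(C)(C)NC=S)CC1`: > 100000 nM
Compound 2 `CC1=CC[C@@H]([C@@](C)(O)CCCC(C)(C)NC(=S)N/N=C\c2ccccc2)CC1`: 20900 nM
Compound 3 `CC1=CC[C@@H]([C@@](C)(O)CCCC(C)(C)NC(=S)N/N=C\c2ccc(N(C)C)cc2)CC1`: 42000 nM

In a functional assay on K562 cells (Homo sapiens) for cytotoxicity, read by sulforhodamine B assay (on this read-out lower numbers stand for stronger inhibition of growth and higher numbers for weaker inhibition of growth), compound 1 gives only a limit, > 100000 nM, and not a number. Compound 2 gives 20900 nM in this assay. Compound 3 gives 42000 nM in this assay. Of the two actual numbers, compound 3 has the higher one, and its nearest neighbour is compound 2, with a 2.0-fold higher number from compound 2 to compound 3 (0.30 log units; within the scatter). The remaining value is the limit of compound 1 (the limit of > 100000 nM in this assay, at which 1 of the 3 values shown sits).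

Compound 4 `CC1=CC[C@@H]([C@@](C)(O)CCCC(C)(C)NC(=S)N/N=C\c2ccccc2Cl)CC1` differs from compound 3 by 2-chlorophenyl in place of 4-(dimethylamino)phenyl on a carbon with a double bond to nitrogen. Within the data shown here, two measured steps bear on this change. The first, an at least 4.7-fold lower number from compound 1 to compound 2 (0.67 log units; beyond the scatter), brought in the whole aromatic-bearing group and was at least modest. The closer one, a 2.0-fold higher number from compound 2 to compound 3 (0.30 log units; within the scatter), altered only the substituent on that aromatic ring and stayed within the scatter. The change to compound 4 again alters only a substituent on the same ring, so no step beyond the scatter is expected, with the number most likely drifting back toward that of compound 2. In this assay compound 4 is therefore estimated at 25000 nM, with a range from 8000 nM to 80000 nM. This estimate corresponds to an expected step of a 1.7-fold lower number from compound 3 to compound 4 (0.23 log units; within the scatter).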

Compound 4, concentration for total growth inhibition: 4110 nM
Beside the measured number, compound 4's estimate is 6.1-fold (0.78 log units) above it; measured number below the stated range.
By their numbers in this assay, from the lowest: compound 4; then compounds 2 and 3 (each within the scatter of the next). At a limit, above all of these: compound 1.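

Among these compounds, the ring substituent at this site, which had so far moved the number only within the scatter, now makes a clear difference in this assay: with 2-chlorophenyl in place of 4-(dimethylamino)phenyl on a carbon with a double bond to nitrogen, the result is a 10-fold lower number from compound 3 to compound 4 (1.01 log units; beyond the scatter). The comparison with the unsubstituted ring isolates a single change, chloro in place of hydrogen on an aromatic carbon, and gives a 5.1-fold lower number from compound 2 to compound 4 (0.71 log units; beyond the scatter), so this substituent takes the number beyond the scatter from the unsubstituted compound as well, which the dimethylamino group of compound 3 did not do. Nothing in the data given accounts for the difference between the chloro and dimethylamino groups.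

The compounds shown leave open whether this step is specific to chloro, since they include no fluoro, bromo, methyl or methoxy group on the ring. They also leave open whether the aromatic ring itself could be replaced, for example by a pyridine or thiophene ring, while keeping the number of compound 4 at 4110 nM.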